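This account rests on a few compounds, and the source may have more. Where it says the series, first, only, none or still open, it means among the compounds named here.

In a functional assay on the whole organism (stomach) with Rattus norvegicus as the target (on this read-out higher numbers stand for an effect only at larger amounts of compound and lower numbers for an effect already at smaller amounts), three compounds have been measured: compound 1 `N#CNC(=N)NCCCCn1nc(-c2ccccc2)ccc1=O` gives 77.2 mg/kg; compound 2 `C/N=C(\S)NCCCCn1nc(-c2ccccc2)ccc1=O` gives 28.9 mg/kg. Compound 3 `C/N=C(\S)NCCCn1nc(-c2ccccc2)ccc1=O` gives only a limit of the assay, > 100 mg/kg.

The change a group of 5 heavy atoms (2 carbon, 3 nitrogen; no ring) in place of a group of 4 heavy atoms (2 carbon, 1 nitrogen, 1 sulfur; no ring), on an amine nitrogen is responsible for the step of a 2.7-fold higher number from compound 2 to compound 1 (0.43 log units; beyond the scatter). The cores of compound 2 and compound 3 differ by a group of 5 heavy atoms (2 carbon, 2 nitrogen, 1 sulfur; no ring) in place of a group of 6 heavy atoms (3 carbon, 2 nitrogen, 1 sulfur; no ring), on a saturated chain carbon, three bonds along the chain from an aromatic nitrogen, and this shortening of the chain gives an at least 3.4-fold higher number from compound 2 to compound 3 (0.53 log units; beyond the scatter). Between compound 1 and compound 3 the step is an at least 1.2-fold higher number from compound 1 to compound 3 (0.11 log units; that floor lies within the scatter).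

Compound 4 `N#CNC(=N)NCCCn1nc(-c2ccccc2)ccc1=O` has not yet been measured. It differs from compound 3 by a group of 5 heavy atoms (2 carbon, 3 nitrogen; no ring) in place of a group of 4 heavy atoms (2 carbon, 1 nitrogen, 1 sulfur; no ring), on an amine nitrogen, the same change that separates compound 2 from compound 1, at the same place on the chain. That change once raised the dose by a 2.7-fold higher number from compound 2 to compound 1 (0.43 log units; beyond the scatter), and compound 3 already sits at the limit (the limit of > 100 mg/kg in this assay, at which 1 of the 3 values shown sits). Compound 4 is therefore expected to need an even larger dose, around 270 mg/kg, with a likely range from 100 mg/kg to 800 mg/kg. The expected step is estimated as a step that the limit leaves unreadable from compound 3 to compound 4, and the assay will most probably report only a limit again.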

Compound 4, dose for half-maximal effect: > 100 mg/kg
Compound 4 gave a limit, no number; the forecaster's own chance of this, stated with the estimate: 85%; the middle value does not contradict the limit.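

In this assay the step from compound 3 to compound 4, like any step that rests on the two limits alone, cannot be read, because both compounds stand at the same limit of the assay, which gives no number for either: the limit of > 100 mg/kg in this assay, at which 2 of the 4 values shown sit. The exchange of groups that gave a 2.7-fold higher number from compound 2 to compound 1 (0.43 log units; beyond the scatter) on the longer chain is therefore neither confirmed nor refuted on the shorter chain, and no size can be given for it there. Only floors can be read, namely an at least 3.4-fold higher number from compound 2 to compound 4 (0.53 log units; beyond the scatter), and an at least 1.2-fold higher number from compound 1 to compound 4 (0.11 log units; that floor lies within the scatter), and the second of these shows no separation from the scatter.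

The compounds shown leave open whether the change would keep its size on a core that gives a readable number in this assay. They also leave open whether a still longer chain, or an amine or a carboxylic acid in place of either group, would bring the shorter-chain series back within the measurable range.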